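The step from compound 2 to compound 4

The compounds below may be only part of what the source reports. "The series", "measured", "known", "first", "only" and "open" are said of these compounds alone.

Measured so far in a physicochemical assay for lipophilicity, using the shake flask method (a lower number here means a more polar compound, a higher number a more lipophilic compound), are three compounds:
compound 1 `Cc1cc(O[C@@H](C)c2c(Cl)ccc(F)c2Cl)ccc1/C=C/C(=O)O` gives 3.2
compound 2 `C[C@H](Oc1cccc(C2CC2)c1)c1c(Cl)ccc(F)c1Cl` gives 5
compound 3 `C[C@H](Oc1ccc2nnc(/C=C/C(=O)O)c(C3CC3)c2c1)c1c(Cl)ccc(F)c1Cl` gives 3.2

Compound 2 has the highest number of the three (5), and the gap to compound 1 (3.2) and to compound 3 (3.2) lies beyond the scatter. Compound 4 `C[C@H](Oc1ccc(NC(=O)CC(N)=O)c(C2CC2)c1)c1c(Cl)ccc(F)c1Cl` has not yet been measured. It departs from compound 2 in one place: ((carbamoylmethyl)carbonyl)amino in place of hydrogen on an aromatic carbon describes ((carbamoylmethyl)carbonyl)amino in place of hydrogen on an aromatic carbon, ortho to a cyclopropyl group and para to a large group. Among the compounds with values here, no pair of measured compounds differs in a single place, so no measured step sets the size of this one, and the expectation rests on the structural change alone. In this assay a downward step beyond the scatter is expected, estimated as a number 1.40 log units lower from compound 2 to compound 4 (beyond the scatter) for this single change. For compound 4 the estimated value is 3.6 (expected range 3 to 4.2).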

Compound 4, distribution coefficient: 3.9
The estimate for compound 4 lay 0.30 log units below the measured number; the range from low to high includes it.
By their numbers in this assay, from the lowest: compounds 1 and 3 (each within the scatter of the next); then compound 4; then compound 2.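

With ((carbamoylmethyl)carbonyl)amino in place of hydrogen on an aromatic carbon, ortho to a cyclopropyl group and para to a large group, this assay moves by a number 1.10 log units lower from compound 2 to compound 4 (beyond the scatter) for this single change. Within the data shown here, this is the first step between measured compounds that differ in one place, so the size of a change at this position now rests on a measurement rather than on a comparison of compounds that differ in several places. Nothing measured here bears on the cause of this step.

The compounds shown leave open how an amine, a carboxylic acid or a shorter chain on the same aromatic carbon would compare with this group. They also leave open whether the same group would give a step of similar size without the cyclopropyl group on the ring.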